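The source may report more compounds than this note shows. Statements on the series, on what has been measured and on what is new or still open speak of the compounds shown alone.

Working notes on a thiophene-ester series bearing a trimethoxyanilino substituent, judged in a functional assay on SEM cells (Homo sapiens) for cytotoxicity, read by MTT assay, with a stated time of 72 h; a lower number here means a stronger inhibitor, a higher number a weaker inhibitor.

Three members have been measured. Compound 1 `COC(=O)c1sc2nc(C)ccc2c1Nc1cc(OC)c(OC)c(OC)c1` gives 0.5 nM. Compound 2 `COC(=O)c1sc2ncccc2c1Nc1cc(OC)c(OC)c(OC)c1` gives 348 nM. Compound 3 `COC(=O)c1sc2ccccc2c1Nc1cc(OC)c(OC)c(OC)c1` gives 179 nM.

Compound 1 and compound 2 differ in one place: methyl in place of hydrogen on an aromatic carbon. This change produced a 700-fold lower number from compound 2 to compound 1 (2.84 log units; beyond the scatter). Compound 3 and compound 2 share the anilino and ester parts but not the core; how the two cores differ is not broken down here, and the values of compound 2 and compound 3 lie within the usual scatter of each other.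

Compound 4 `COC(=O)c1sc2ccc(C)cc2c1Nc1cc(OC)c(OC)c(OC)c1` is not yet measured. It is made from compound 3 by the change (methyl in place of hydrogen on an aromatic carbon). This is the same kind of change as that from compound 2 to compound 1, but not the same: in compound 1 the methyl sits on a six-membered aromatic ring with 1 nitrogen, next to the ring nitrogen, whereas in compound 4 it sits on a six-membered aromatic ring of carbon only. Among the measured compounds shown here, only one such step is known, and its ring context is not that of compound 4.

For compound 4 the step is expected to be a 9.0-fold lower number from compound 3 to compound 4 (0.95 log units; beyond the scatter), smaller than the earlier step, because the earlier step of a 700-fold lower number from compound 2 to compound 1 (2.84 log units; beyond the scatter) stands alone and its place is not repeated here. Compound 4 is therefore estimated at 20 nM, with a plausible span from 2 nM to 200 nM.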

Compound 4, half-maximal inhibitory concentration: 185 nM
The estimate for compound 4 lay 9.3-fold (0.97 log units) below the measured number; measured number inside the range.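

In this assay, methyl in place of hydrogen on an aromatic carbon of the core of compound 3 gives a 1.0-fold higher number from compound 3 to compound 4 (0.01 log units; within the scatter), so the large step seen on the core of compound 2 does not carry over to this core at the place occupied in compound 4. The same kind of change therefore cannot be treated as a fixed increment across these two cores: the same change on two cores in this assay, a 700-fold lower number (2.84 log units; beyond the scatter) from compound 2 to compound 1 and a 1.0-fold higher number (0.01 log units; within the scatter) from compound 3 to compound 4, 720-fold (2.86 log units) apart, beyond the scatter of two such steps This does not show what sets the difference, since each core supplies a single pair, and the methyl sits on a six-membered aromatic ring with 1 nitrogen in compound 1 but on a six-membered aromatic ring of carbon only in compound 4, so the core and the place of the methyl cannot be separated.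

The compounds shown leave open whether the large step on the core of compound 1 is specific to methyl or would also appear with ethyl, chlorine or an amine on that carbon, and whether methyl on another carbon of the core of compound 3 would give a step beyond the scatter. Also open, on these data alone, is whether the value of compound 1, 0.5 nM, would hold with a carboxylic acid or an amide in place of the ester.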